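The source may report more compounds than this note shows. Statements on the series, on what has been measured and on what is new or still open speak of the compounds shown alone.

The measured compounds:

compound 1, `COC(OC)C1OC(C)(C)OC1Cc1cnc2ccccc2n1`: in a functional assay on EC9706 cells (Homo sapiens) for cytotoxicity, read by MTT assay, with a stated time of 48 h (on this read-out higher numbers stand for weaker inhibition and lower numbers for stronger inhibition), compound 1 sits at the limit of > 100 ug/mL and gives no number.
compound 2, `COC(OC)C1OC(C)(C)OC1Cc1cnc2ccc(Cl)cc2n1`: in this assay compound 2 gives 30.5 ug/mL.

Among the measured compounds shown here, compound 2 therefore holds the only number; the remaining value is a limit, as described by the limit of > 100 ug/mL in this assay, at which 1 of the 2 values shown sits. For the measured compounds named here, the one measured step, an at least 3.2-fold lower number from compound 1 to compound 2 (0.51 log units; beyond the scatter), places a substituent on the aromatic carbon that carries hydrogen in compound 1.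

Compound 3, `COC(OC)C1OC(C)(C)OC1Cc1cnc2ccc(C(=O)c3ccccc3)cc2n1`, keeps the whole core of compound 2 and changes only the same position: benzoyl in place of chloro on an aromatic carbon. Going by the values given here, no measured step compares two different substituents at that carbon, so the step from compound 1 to compound 2 is the only guide, and it shows that this position is responsive. A benzoyl group differs from chloro in size and in carrying a hydrogen-bond acceptor, and the data give no measured effect for either feature.

On that basis the step of a 1.5-fold lower number from compound 2 to compound 3 (0.18 log units; within the scatter) is expected to stay modest, with the number of compound 3 estimated around 20 ug/mL, between 6 ug/mL and 70 ug/mL.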

Compound 3, half-maximal inhibitory concentration: 80 ug/mL
Compound 3: the middle estimate sits 4.0-fold (0.60 log units) below what was measured; the whole stated range lies below it.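

At the aromatic carbon that carries the new group, the identity of the substituent now proves to matter in this assay: benzoyl in place of chloro gives a 2.6-fold higher number from compound 2 to compound 3 (0.42 log units; beyond the scatter), so inhibition here is weaker with benzoyl than with chloro. The earlier step showed only that replacing hydrogen with chloro at this carbon lowers the number, whereas the comparison with hydrogen now gives an at least 1.2-fold lower number from compound 1 to compound 3 (0.09 log units; that floor lies within the scatter), so these data do not establish that benzoyl offers any gain over hydrogen. Compound 1 stands at a limit and gives no number, which leaves the true size of that step open: the limit of > 100 ug/mL in this assay, at which 1 of the 3 values shown sits.

Which part of benzoyl, its carbonyl or its aromatic ring, accounts for the step from chloro remains open, since the compounds shown never vary the two separately. Also open, from the compounds shown here alone, is how this carbon would respond to other groups, such as bromo, methoxy, an amine or a carboxylic acid, and whether any of them would give a lower number than chloro.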